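The source may hold more compounds than are shown below. What is called first, only, known or untested is meant among the compounds shown, and "the series" means these compounds.

Of the compounds shown here, three have been measured in an ADME assay on RAW264.7 cells (Mus musculus) for cytotoxicity, read by MTT assay, with a stated time of 48 h (on this read-out lower numbers stand for higher toxicity in this test and higher numbers for lower toxicity in this test), so far. Compound 1 `C#CCN(c1nc(-c2cccc([N+](=O)[O-])c2)no1)C1CCCCC1` gives 34.2 ug/mL. Compound 2 `CC(=O)OC[C@H]1O[C@H](OC[C@@H](Cn2cc(CN(c3nc(-c4ccc(C)cc4)no3)C3CCCCC3)nn2)OC(C)=O)C=C[C@@H]1OC(C)=O` gives 45.3 ug/mL. Compound 3 `C#CCN(c1nc(-c2ccc(Cl)cc2)no1)C1CCCCC1` gives 15.1 ug/mL. Compound 2 and compound 1 lie within the usual scatter of each other, so nothing separates them; compound 3, however, sits beyond the scatter below compound 2, meaning compound 3 is the more toxic of these two in this assay.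

Compound 4 `CC(=O)OC[C@H]1O[C@H](OC[C@@H](Cn2cc(CN(c3nc(-c4ccc(C(F)(F)F)cc4)no3)C3CCCCC3)nn2)OC(C)=O)C=C[C@@H]1OC(C)=O` is not yet measured. It differs from compound 2 in one place: trifluoromethyl in place of methyl on an aromatic carbon, para to a large group. Among the compounds with values here, no pair of measured compounds shows this same change, so no measured step can guide the expectation; compound 1 and compound 3 carry other groups on another core, and their numbers only show that varying the group on this ring can move the read-out beyond the scatter. The step from compound 2 to compound 4 is therefore expected to be modest, a 1.4-fold lower number from compound 2 to compound 4 (0.15 log units; within the scatter), toward a somewhat lower number. Compound 4 is estimated at 32 ug/mL in this assay, within a range from 14 ug/mL to 75 ug/mL.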

Compound 4, half-maximal cytotoxic concentration: 64.1 ug/mL
For compound 4 the middle estimate is 2.0-fold (0.30 log units) below the measured one, within the range that was stated.
By their numbers in this assay, from the lowest: compound 3; then compounds 1, 2 and 4 (each within the scatter of the next).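

In this assay, within the data shown here, putting trifluoromethyl in place of methyl on an aromatic carbon, para to a large group, gives a 1.4-fold higher number from compound 2 to compound 4 (0.15 log units; within the scatter) and is the first step measured at this position. In this one pair, then, a group of 4 heavy atoms can replace a group of 1 heavy atom at this position without separating the two compounds on this read-out, so the earlier finding that ring groups can matter on another core does not carry over to this change. Nothing available here explains this result.

On these data alone, whether a different group on this aromatic carbon, such as an amine, a carboxylic acid or a longer chain, would give a step beyond the scatter stays open. This single pair also leaves open how the same change would behave on the core of compound 1.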